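From a Free Hydroxy to a Phenoxy Group

This account rests on a few compounds, and the source may have more. Where it says the series, first, only, none or still open, it means among the compounds named here.

Compound 2 `CC1(C)Cc2c(O)cc(C(=O)O)cc2O1` has been tested in a functional assay on the whole organism with Homo sapiens as the target, read by hemolysis; on this read-out lower numbers stand for stronger inhibition and higher numbers for weaker inhibition. In this assay compound 2 reaches only the limit of the assay, > 1440000 nM. Compound 1 `CC1(C)Cc2c(O)cc(C=O)cc2O1` differs from it by hydroxy in place of hydrogen on a carbonyl carbon. In this assay compound 1 likewise sits at a limit, > 1560000 nM. Hence the step that the two limits leave unreadable from compound 1 to compound 2 cannot be sized. Compound 3 `CC1(C)Cc2c(Oc3ccccc3)cc(C(=O)O)cc2O1` carries phenyl in place of hydrogen on an oxygen on an aromatic ring. Among the measured compounds shown here, no measured step bears on this change, and both known values are limits. Compound 3 is therefore expected at 1000000 nM, between 200000 nM and 3000000 nM, an estimated step of an at least 1.4-fold lower number from compound 2 to compound 3 (0.15 log units; that floor lies within the scatter) within the scatter.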

Compound 3, half-maximal inhibitory concentration: > 1050000 nM
Compound 3: a limit, no number (the forecaster's own chance of this, stated with the estimate: 70%); middle value at least 1.0-fold (0.02 log units) from the limit.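

The value of compound 3 is a limit, > 1050000 nM and not a number. Compound 2 also sits at a limit, so the step between them cannot be read. The compounds shown leave open whether hydroxy to phenoxy changes inhibition at all.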